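This account rests on a few compounds, and the source may have more. Where it says the series, first, only, none or still open, it means among the compounds named here.

Measured compounds:
compound 1, `COc1ccc(Cn2nnc(O)c2C(=O)Nc2cc(C(F)(F)F)cc(C(F)(F)F)c2)cc1`, 2.47
compound 2, `COc1ccc(Cn2nnc(O)c2C(=O)Nc2ccc(-c3ccccc3)cc2)cc1`, 2.19
compound 3, `COc1ccc(Cn2nnc(O)c2C(=O)Nc2cccc(-c3ccc(O)cc3)c2)cc1`, 2.19

In a physicochemical assay for lipophilicity, read by spectrophotometry, using the shake flask method, in phosphate buffer, measured as octanol-water partition, with a stated time of 4 h, at pH 7.4 (on this read-out lower numbers stand for lower lipophilicity and higher numbers for higher lipophilicity), compound 3 gives 2.19 and stands level with compound 2 at the digits printed, the two together being the lowest of the three numbers; compound 1 lies a little higher, but within the scatter of this assay, so no order among the three can be claimed.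

Compound 4, `COc1ccc(Cn2nnc(O)c2C(=O)Nc2cccc(-c3cccc(OC)c3)c2)cc1`, is yet to be measured in this assay. It differs from compound 3 in one place: 3-methoxyphenyl in place of 4-hydroxyphenyl on an aromatic carbon.

Among the compounds with values here, no step between measured compounds is known here, so the expected size rests on the values alone. Since compound 2 gives 2.19 with no hydroxyl present, the exchange of 4-hydroxyphenyl for 3-methoxyphenyl is expected to give a small step upward, of about a number 0.21 log units higher from compound 3 to compound 4 (within the scatter), near the edge of the scatter. Compound 4 is therefore estimated at 2.4, with a range from 2 to 2.8.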

Compound 4, distribution coefficient: 2.5
Compound 4: the middle estimate sits 0.10 log units below what was measured, within the range that was stated.
By their numbers in this assay, from the lowest: compounds 2, 3, 1 and 4 (each within the scatter of the next, the first and the last beyond it).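

In this assay, within the data shown here, the exchange of 4-hydroxyphenyl for 3-methoxyphenyl gives a number 0.31 log units higher from compound 3 to compound 4 (beyond the scatter) and so offers the first one-place comparison. The earlier compounds shown here differ from one another in more than one place, so they could not show that a change at this aromatic carbon alone moves the read-out beyond the scatter. Among these compounds, the single step combines two differences, as the hydrogen-bond donor of the leaving group is gone and the substituent on the phenyl ring has a different name and number, and nothing available here accounts for the step.

The compounds shown leave open how far each of those two differences contributes to the step. They also leave open how this assay would read with an amine or a carboxylic acid on that phenyl ring.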